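Trimming one methoxy from compound 3: expectation for compound 4

The compounds below may be only part of what the source reports. "The series", "measured", "known", "first", "only" and "open" are said of these compounds alone.

In a functional assay on NCI/ADR-RES cells (Homo sapiens) for cytotoxicity, read by sulforhodamine B assay, with a stated time of 48 h, tested at 1 uM (on this read-out lower numbers stand for a stronger effect and higher numbers for a weaker effect at the one concentration tested), compound 1 `COc1ccc(-c2cc(/C=C/C(=O)c3ccc(N)cc3)[nH]n2)cc1` gives 85%, compound 2 `COc1ccc(-c2cc(/C=C/C(=O)c3ccc(N)cc3)[nH]n2)cc1OC` gives 99% and compound 3 `COc1cc(C(=O)/C=C/c2cc(-c3cc(OC)c(OC)c(OC)c3)n[nH]2)cc(OC)c1OC` gives 95%. Compound 4 `COc1ccc(-c2cc(/C=C/C(=O)c3cc(OC)c(OC)c(OC)c3)[nH]n2)cc1OC` is not yet measured there. The difference between the cores of compound 2 and compound 3 is not broken down here. Compound 1 arises from compound 2 by hydrogen in place of methoxy on an aromatic carbon. Compound 4 arises from compound 3 by hydrogen in place of methoxy on an aromatic carbon. The two changes are the same kind of change, not the same: in compound 3 the place is also meta to a methoxy group. The one measured case of this change, a number 14 percentage points lower from compound 2 to compound 1 (beyond the scatter), is modest and beyond the scatter. Compound 2 and compound 3 lie within the scatter of each other. For compound 4 a step of similar size is expected, a number 11 percentage points lower from compound 3 to compound 4 (beyond the scatter), resting on that single measured step. Compound 4 is therefore estimated at 84%, between 70% and 98%.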

Compound 4, a percentage reported as activity, at one concentration (the size of the read-out at that concentration, not a potency): 81%
The estimate for compound 4 lay 3 percentage points above the measured number, within the range that was stated.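

In this assay, hydrogen in place of methoxy on an aromatic carbon carries over between two cores, with a number 14 percentage points lower from compound 3 to compound 4 (beyond the scatter) matching the earlier step: the same change on two cores in this assay, a number 14 percentage points lower (beyond the scatter) from compound 2 to compound 1 and a number 14 percentage points lower (beyond the scatter) from compound 3 to compound 4, 0 percentage points apart, within the scatter of two such steps
The agreement holds even though the place in compound 3 is also meta to a methoxy group. Within the data shown here, it rests on only two pairs at a single concentration, so it does not establish a rule for other cores, show how the effect would shift at other concentrations, or give a reason for the lower number.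

The compounds shown leave open whether the step would hold on a third core. They also leave open what ethoxy, hydroxyl or fluorine would do at this place on the ring in place of methoxy or hydrogen.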